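Unbound fraction notes: pyrimidin-5-yl on compound 1

The source may report more compounds than this note shows. Statements on the series, on what has been measured and on what is new or still open speak of the compounds shown alone.

Measured in an ADME assay on a cell-free system (plasma, Homo sapiens); a lower number here means a smaller unbound share, a higher number a larger unbound share of the compound:
- compound 1 `CCNC(=O)Nc1nc2cc(-c3cccnc3)c(=O)n(C(C)C)c2s1`: 0.21
- compound 2 `CCNC(=O)Nc1nc2cc(-c3cccnc3)c(=O)n(CC3CCOCC3)c2s1`: 0.14

Within the data shown here, only two numbers exist so far, and compound 1 gives 0.21. Among the measured compounds shown here, its one neighbour sits close by, as the step shows: a 1.5-fold lower number from compound 1 to compound 2 (0.18 log units; within the scatter). The two cannot be ordered on these data.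

The next compound to be measured is compound 3 `CCNC(=O)Nc1nc2cc(-c3cncnc3)c(=O)n(C(C)C)c2s1`. It keeps the core of compound 1 and carries pyrimidin-5-yl in place of pyridin-3-yl on an aromatic carbon.

For the measured compounds named here, no measured step covers this change. Going by the values given here, the single step available, (oxan-4-yl)methyl in place of isopropyl on an aromatic nitrogen, lies at a different place on the molecule, so it bears only indirectly. It does show that a larger change of group on compound 1 moved this assay by no more than a 1.5-fold lower number from compound 1 to compound 2 (0.18 log units; within the scatter). On that slim basis, no shift beyond the scatter is expected, with a slight lean towards a higher number. The expected step is a 1.2-fold higher number from compound 1 to compound 3 (0.09 log units; within the scatter). The estimated value for compound 3 is 0.26, with an expected range of 0.14 to 0.45.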

Compound 3, unbound fraction: 0.15
Compound 3: middle estimate off by 1.7-fold (0.24 log units), on the high side; the measured number falls inside the stated range.
By their numbers in this assay, from the lowest: compounds 2, 3 and 1 (each within the scatter of the next).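

In this assay, the aromatic carbon that carries pyridin-3-yl now has a measured step of its own, with pyrimidin-5-yl in its place giving a 1.4-fold lower number from compound 1 to compound 3 (0.15 log units; within the scatter) and staying within the scatter. At this position, with the count of 6 heavy atoms unchanged, a six-membered aromatic ring with 2 hetero atoms therefore cannot be told apart from one with 1 hetero atom on these data, and the same holds at the aromatic nitrogen, where (oxan-4-yl)methyl in place of isopropyl gives a 1.5-fold lower number from compound 1 to compound 2 (0.18 log units; within the scatter) and also stays within the scatter. No supporting measurement bears on this result, so the step stands without an explanation.

The compounds shown leave open whether any group on this aromatic carbon can move the unbound fraction beyond the scatter, for example an amine, a carboxylic acid or a phenyl ring carrying either one in place of pyridin-3-yl. Also open, on these data alone, is whether pyrimidin-5-yl behaves the same way when (oxan-4-yl)methyl rather than isopropyl sits on the aromatic nitrogen.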